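Cytotoxicity of biaryl amide acids and esters in liver cells

This account rests on a few compounds, and the source may have more. Where it says the series, first, only, none or still open, it means among the compounds named here.

The measured compounds and their values:
Compound 1, `COc1ccc(F)c(-c2ccc(C(=O)N(Cc3cccc(OCCCCCC(=O)O)c3)C(C)C)cc2)c1`, gives > 26000 nM in an ADME assay on HepG2 cells (Homo sapiens) for cytotoxicity, read by CellTiter-Glo and resazurin assay, with a stated time of 72 h; on this read-out higher numbers stand for an effect only at larger amounts of compound and lower numbers for an effect already at smaller amounts.
Compound 2, `CC(C)N(Cc1cccc(OCCCCCC(=O)O)c1)C(=O)c1ccc(-c2cccc(F)c2)cc1`, gives > 26000 nM in this assay.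
Compound 3, `CCOC(=O)CCCCCOc1cccc(CN(C(=O)c2ccc(-c3cc(OC)ccc3F)cc2)C(C)C)c1`, gives > 26000 nM in this assay.

Each of these three values is a limit of the assay and not a number. Compound 1 stands at a limit. Compound 2 stands at a limit. Compound 3 stands at a limit. All three sit at the limit of > 26000 nM in this assay, at which 3 of the 3 values shown sit. From compound 1 to compound 2 the change is 3-fluorophenyl in place of 2-fluoro-5-methoxyphenyl on an aromatic carbon, and the step is a step that the two limits leave unreadable from compound 1 to compound 2. From compound 1 to compound 3 the change is ethyl in place of hydrogen on an oxygen next to a carbonyl group, and the step is a step that the two limits leave unreadable from compound 1 to compound 3.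

Compound 4, `CCOC(=O)CCCCCOc1cccc(CN(C(=O)c2ccc(-c3cccc(F)c3)cc2)C(C)C)c1`, is not yet measured. It differs from compound 3 by 3-fluorophenyl in place of 2-fluoro-5-methoxyphenyl on an aromatic carbon, the same change that is made from compound 1 to compound 2. Since compound 3 sits at a limit and the earlier step to compound 2 stayed at a limit, compound 4 is expected to stay at a limit as well, with a step of about a number no higher from compound 3 to compound 4 (the limit leaves the size open). The estimated value of compound 4 in this assay is 26000 nM, between 13000 nM and 60000 nM.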

Compound 4, half-maximal effective concentration: > 26000 nM
Compound 4: only a limit was reported; the forecaster's own chance of this, stated with the estimate: 90%; the middle value lies on the limit itself.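

In this assay compound 4 gives > 26000 nM, which is a limit and not a number. No step to compound 4 from compound 2 or compound 3 can be read, because all the values share one limit: the limit of > 26000 nM in this assay, at which 4 of the 4 values shown sit.

The compounds shown leave open where the cytotoxicity of each one actually lies, and whether either change alters it.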